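This account rests on a few compounds, and the source may have more. Where it says the series, first, only, none or still open, it means among the compounds named here.

Compound 1 `C/N=C(\NC#N)NCCSCn1nc(C)ccc1=O`: in a functional assay on the whole organism (stomach) for inhibition, with Rattus norvegicus as the target, with a stated time of 4 h (on this read-out higher numbers stand for an effect only at larger amounts of compound and lower numbers for an effect already at smaller amounts), compound 1 gives > 100 mg/kg, which is a limit of the assay.
Compound 2 `C/N=C(\NC#N)NCCSCn1nc(-c2ccccc2)ccc1=O`: in this assay compound 2 gives < 30.5 mg/kg, again a limit.
Compound 3 `C/N=C(\NC#N)NCCSCn1nc(-c2ccc(C)cc2)ccc1=O`: in this assay compound 3 gives < 53.8 mg/kg, also a limit.

Compound 2 thus stands only at a limit, with no number of its own. Compound 4 `CCC/N=C(\NC#N)NCCSCn1nc(-c2ccccc2)ccc1=O` differs from it by ethyl in place of hydrogen on a saturated chain carbon bound to a double-bonded nitrogen. The measured steps all sit elsewhere: an at least 3.2-fold lower number from compound 1 to compound 2 (0.51 log units; beyond the scatter), an at least 1.8-fold lower number from compound 1 to compound 3 (0.26 log units; that floor lies within the scatter) and a step that the two limits leave unreadable from compound 2 to compound 3 concern the group on the aromatic carbon, not the chain carbon bound to the double-bonded nitrogen. Within the data shown here, no measured step bears on the change from compound 2 to compound 4, and no step beyond the scatter is expected in this assay; the expected step is a step that the limit leaves unreadable from compound 2 to compound 4. Compound 4 is estimated at 20 mg/kg, within 6 mg/kg to 60 mg/kg.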

Compound 4, dose for half-maximal effect: > 100 mg/kg
Compound 4 ended at the assay's limit; the forecaster's own chance of this, stated with the estimate: 60%; at least 5.0-fold (0.69 log units) between middle value and limit.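

In this assay, the saturated chain carbon bound to a double-bonded nitrogen now has a readable step: ethyl in place of hydrogen gives an at least 3.2-fold higher number from compound 2 to compound 4 (0.51 log units; beyond the scatter). The earlier steps shown here concerned only the group on the aromatic carbon, whereas this one shows that the chain end does not freely accept added carbon when phenyl is kept. Both ends of the step are limits, so it gives a floor and not a size.

Open, from the compounds shown here alone, is how the read-out changes with a methyl, a longer chain or an amine at this carbon. Also open, going by these compounds, is whether ethyl has the same effect with 4-methylphenyl on the aromatic carbon.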